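The source may hold more compounds than are shown below. What is called first, only, known or untested is meant among the compounds shown, and "the series" means these compounds.

Measured compounds:
- compound 1 `CCC/N=C(\S)OC[C@H]1OC(n2cnc3c(NC4CCOC4)ncnc32)[C@H](O)[C@@H]1O`, in an assay on DDT1 cells (Cricetulus griseus) for binding affinity to adenosine receptor A1 (Homo sapiens), read by radioligand binding (on this read-out higher numbers stand for weaker inhibition and lower numbers for stronger inhibition), compound 1 gives 50 nM
- compound 2 `O=C(NC1CCCCC1)OC[C@H]1OC(n2cnc3c(NC4CCOC4)ncnc32)[C@H](O)[C@@H]1O`, in this assay compound 2 gives 584 nM

Going by the values given here, compound 2 stands at the higher of these two numbers; its only neighbour is compound 1, and the step of a 12-fold higher number from compound 1 to compound 2 (1.07 log units; beyond the scatter) separates them. Compound 3 `O[C@@H]1[C@@H](CO/C(S)=N/Cc2ccccc2)OC(n2cnc3c(NC4CCOC4)ncnc32)[C@@H]1O` is not yet measured. It differs from compound 2 by a group of 10 heavy atoms (8 carbon, 1 nitrogen, 1 sulfur; one six-membered aromatic ring of carbon only) in place of a group of 9 heavy atoms (7 carbon, 1 nitrogen, 1 oxygen; one six-membered non-aromatic ring of carbon only), on an oxygen on a saturated carbon. Among the compounds with values here, the entering group, like the group carried by compound 1, holds sulfur and nitrogen without the carbonyl of the carbamate that leaves, so the one measured step bearing on this change is a 12-fold higher number from compound 1 to compound 2 (1.07 log units; beyond the scatter), which is read here in reverse. Within the data shown here, compound 3 is therefore expected to move in this assay towards a lower number than compound 2, by a step of about a 7.3-fold lower number from compound 2 to compound 3 (0.86 log units; beyond the scatter), as the benzyl substituent on the entering group has no measured counterpart among the two compounds. The estimate for compound 3 is 80 nM, with a range from 20 nM to 400 nM.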

Compound 3, inhibition constant: 12 nM
Beside the measured number, compound 3's estimate is 6.7-fold (0.82 log units) above it, and the stated range ends above it.
By their numbers in this assay, from the lowest: compound 3; then compound 1; then compound 2.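

In this assay, phenyl in place of ethyl on a saturated chain carbon bound to a double-bonded nitrogen gives a 4.2-fold lower number from compound 1 to compound 3 (0.62 log units; beyond the scatter), so the sulfur-bearing group on this oxygen can carry an aromatic ring while the number still falls. Replacing cyclohexylcarbamoyl with the entering group gives a 49-fold lower number from compound 2 to compound 3 (1.69 log units; beyond the scatter), the largest step among these compounds, although this change alters both the ring and the group that links it to the oxygen. No measurement is available here that would explain either step.

The compounds shown leave open how this larger step divides between the ring and the linking group, a question that a cyclohexyl on the sulfur-bearing group or a benzyl carbamate could address. On these data alone, how a longer chain or a pyridine ring would behave in place of the phenyl also remains open.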